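The source may report more compounds than this note shows. Statements on the series, on what has been measured and on what is new or still open speak of the compounds shown alone.

Cytotoxicity notes for the series, read in an ADME assay on Raji cells (Homo sapiens) for cytotoxicity, read by CellTiter-Glo and resazurin assay, with a stated time of 72 h; on this read-out lower numbers stand for an effect already at smaller amounts and higher numbers for an effect only at larger amounts of compound. Compound 1 `Cc1nnc(-c2cccc(-c3ccc(C(=O)N(Cc4cccc(OCCCCCC(=O)O)c4)C(C)C)cc3)c2)o1` is recorded only as a limit of the assay and not as a number: in this assay compound 1 gives > 26000 nM. Compound 2 `CCOC(=O)CCCCCOc1cccc(CN(C(=O)c2ccc(-c3cccc(-c4nnc(C)o4)c3)cc2)C(C)C)c1` likewise stands at a limit: in this assay compound 2 gives > 26000 nM. For the measured compounds named here, the one measured step, a step that the two limits leave unreadable from compound 1 to compound 2, is therefore of unreadable size, and compound 2 stands where every value shown stands, as the tally the limit of > 26000 nM in this assay, at which 2 of the 2 values shown sit, records. Compound 3 `CCOC(=O)CCCCCOc1cccc(CN(C(=O)c2ccc(-c3cccc([N+](=O)[O-])c3)cc2)C(C)C)c1` differs from compound 2 by nitro in place of 5-methyl-1,3,4-oxadiazol-2-yl on an aromatic carbon. Going by the values given here, no measured step concerns this part of the structure, and the single step that the two limits leave unreadable from compound 1 to compound 2 gives no size to carry over. With both values at the limit, compound 3 is expected to return a limit as well, and the expected step that the limit leaves unreadable from compound 2 to compound 3 is none beyond the scatter. For compound 3 the estimate in this assay is 40000 nM, between 15000 nM and 150000 nM.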

Compound 3, half-maximal effective concentration: > 26000 nM
Compound 3 gave a limit, no number; the forecaster's own chance of this, stated with the estimate: 85%; the middle value lies beyond the limit too.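

Compound 2 and compound 3 both stand only at a limit in this assay, not at a number, so exchanging 5-methyl-1,3,4-oxadiazol-2-yl for nitro gives no readable step. The compounds shown leave open whether any change to the shared core gives a measurable value in this assay.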